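The source may report more compounds than this note shows. Statements on the series, on what has been measured and on what is new or still open speak of the compounds shown alone.

For the measured compounds named here, compound 2 `COc1ccc(N/C=N/C2=C(C#N)C3C(N4CCCC4)CCCCN3C(=O)N2c2ccccc2)cc1` stands highest of the two numbers so far in a functional assay on the whole organism (strain albino) for inhibition, with Rattus norvegicus as the target, read by paw edema, with stated times of 1 h and 2 h, at a dose of 20 mmol/kg by the intraperitoneal route (on this read-out lower numbers stand for less inhibition and higher numbers for more inhibition at the one dose given (going by the name of the read-out)), where compound 2 gives 37.2%. Compound 1 `N#CC1=C(NCN2CCCC2)N(c2ccccc2)C(=O)N2CCCCC(N3CCCC3)C12` gives 26.6% in this assay, so the step of a number 10.6 percentage points higher from compound 1 to compound 2 (beyond the scatter) is the only measured one. Compound 3 `COc1ccc(/C=N/C2=C(C#N)C3C(N4CCCC4)CCCCN3C(=O)N2c2ccccc2)cc1` differs from compound 2 by 4-methoxyphenyl in place of (4-methoxyphenyl)amino on a carbon with a double bond to nitrogen. The measured step changed a different group and does not bear on this loss of the amino link, so no direction is indicated and a step within the scatter is expected. Compound 3 is therefore estimated at 33% in this assay, between 20% and 46%. The step of a number 4.2 percentage points lower from compound 2 to compound 3 (within the scatter) is expected to fall within the scatter.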

Compound 3, a percentage reported as inhibition, in the whole organism at one dose (the size of the read-out at that dose, not a potency): 71.6%
Estimate against measurement, compound 3: 38.6 percentage points below; measured number outside the range, above it.
By their numbers in this assay, from the lowest: compound 1; then compound 2; then compound 3.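

In this assay, losing the amino link on this carbon with a double bond to nitrogen gives a number 34.4 percentage points higher from compound 2 to compound 3 (beyond the scatter), although both compounds carry the 4-methoxyphenyl ring, so the link matters as well as the ring. Against the group in compound 1, the group in compound 3 gives a number 45 percentage points higher from compound 1 to compound 3 (beyond the scatter). No measurement available explains the effect of this change.

Going by these compounds, whether this rise is specific to 4-methoxyphenyl remains open; unsubstituted phenyl or 4-chlorophenyl on the same carbon would test that. On these data alone, whether the order holds at other doses also remains open.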